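A few compounds are considered here, and "the series" means these few. Any claim that something is new, unique, unknown or untested is made for them only; others in the source may bear on it.

Measured so far in a functional assay on MCF7 cells (Homo sapiens) for cytotoxicity, read by MTT assay, with a stated time of 96 h; a lower number here means a stronger inhibitor, a higher number a weaker inhibitor:
compound 1, `COc1cc(C(=O)c2cn(-c3cccc(N)c3)cc2-c2cccc(N)c2)cc(OC)c1OC`: 60 nM
compound 2, `COc1cc(C(=O)c2cn(-c3cccc(N)c3)cc2-c2ccc(N)cc2)cc(OC)c1OC`: 14 nM
compound 3, `COc1cc(C(=O)c2cn(-c3ccc(C)cc3)cc2-c2cccc(N)c2)cc(OC)c1OC`: 53 nM

Within the core shared by compound 1 and compound 2, the change 4-aminophenyl in place of 3-aminophenyl on an aromatic carbon gave a 4.3-fold lower number from compound 1 to compound 2 (0.63 log units; beyond the scatter). Compound 3 sits on a different core; the two cores differ by 4-methylphenyl in place of 3-aminophenyl on an aromatic nitrogen, and that switch gave a 1.1-fold lower number from compound 1 to compound 3 (0.05 log units; within the scatter), so compound 1 and compound 3 are not told apart by this assay.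

Compound 4, `COc1cc(C(=O)c2cn(-c3ccc(C)cc3)cc2-c2ccc(N)cc2)cc(OC)c1OC`, is not yet measured. It differs from compound 3 by 4-aminophenyl in place of 3-aminophenyl on an aromatic carbon. Within the data shown here, the place is not the same word for word: in compound 1 the ring atom two ring bonds away bears a 3-aminophenyl group, in compound 3 a 4-methylphenyl group, so this is the same kind of change rather than the same change, and it has only one measured instance.

Among the measured compounds shown here, for compound 4 the expected step is a 4.1-fold lower number from compound 3 to compound 4 (0.61 log units; beyond the scatter), resting on a 4.3-fold lower number from compound 1 to compound 2 (0.63 log units; beyond the scatter) as the single precedent. Compound 4 is estimated at 13 nM, between 6 nM and 30 nM.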

Compound 4, half-maximal inhibitory concentration: 6 nM
Compound 4: middle estimate off by 2.2-fold (0.34 log units), on the high side, and the stated range covers the measured number.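

In this assay, 4-aminophenyl in place of 3-aminophenyl on an aromatic carbon gave an 8.8-fold lower number from compound 3 to compound 4 (0.95 log units; beyond the scatter), and this step carries from one core to the other without a difference beyond the scatter: the same change on two cores in this assay, a 4.3-fold lower number (0.63 log units; beyond the scatter) from compound 1 to compound 2 and an 8.8-fold lower number (0.95 log units; beyond the scatter) from compound 3 to compound 4, 2.1-fold (0.31 log units) apart, within the scatter of two such steps

4-methylphenyl in place of 3-aminophenyl on an aromatic nitrogen gave a 2.3-fold lower number from compound 2 to compound 4 (0.37 log units; beyond the scatter), and this change also carries across, although only this instance lies beyond the scatter: the same change on two cores in this assay, a 1.1-fold lower number (0.05 log units; within the scatter) from compound 1 to compound 3 and a 2.3-fold lower number (0.37 log units; beyond the scatter) from compound 2 to compound 4, 2.1-fold (0.31 log units) apart, within the scatter of two such steps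

Among these compounds, each comparison rests on only two cores, so the agreement holds for these four compounds and does not establish transfer to other cores or explain the steps.

Still open, as far as these compounds go, is how a 4-hydroxyphenyl or 4-chlorophenyl group would compare with 4-aminophenyl on the aromatic carbon. Also open, from the compounds shown here alone, is how a plain phenyl would compare with 4-methylphenyl on the aromatic nitrogen.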